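Sulfonylpiperazine amides: amide substituent changes against the cytotoxicity limit

The source may hold more compounds than are shown below. What is called first, only, known or untested is meant among the compounds shown, and "the series" means these compounds.

Compound 2 `CC(C(=O)N(C)Cc1ccccc1)N1CCN(S(=O)(=O)c2ccc(C(C)(C)C)cc2)CC1` is one of two amides on the shared core that have been measured in an ADME assay on HepG2 cells (Homo sapiens) for inhibition, with a stated time of 48 h; on this read-out lower numbers stand for an effect already at smaller amounts and higher numbers for an effect only at larger amounts of compound. In this assay compound 2 gives > 40000 nM, which is a limit of the assay and not a number. Compound 1 `CC(C(=O)N1CCc2ccccc21)N1CCN(S(=O)(=O)c2ccc(C(C)(C)C)cc2)CC1` likewise gives > 40000 nM in this assay, again a limit. The step that the two limits leave unreadable from compound 1 to compound 2 therefore cannot be read; both values sit at the limit of > 40000 nM in this assay, at which 2 of the 2 values shown sit.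

Compound 3 `CC(C(=O)N1CCc2ccccc2C1C)N1CCN(S(=O)(=O)c2ccc(C(C)(C)C)cc2)CC1` is not yet measured. It differs from compound 2 by 1-methyl-1,2,3,4-tetrahydroisoquinolin-2-yl in place of benzyl(methyl)amino on a carbonyl carbon. Among the compounds with values here, the only measured step that bears on this position is the one from compound 1 to compound 2, and it is unreadable because the limit of > 40000 nM in this assay, at which 2 of the 2 values shown sit, covers both ends. The step from benzyl(methyl)amino to 1-methyl-1,2,3,4-tetrahydroisoquinolin-2-yl is expected to behave the same way: the expected step is a step that the limit leaves unreadable from compound 2 to compound 3, nothing beyond the scatter. Compound 3 is estimated to give 60000 nM in this assay, with a range from 25000 nM to 200000 nM, most probably reported once more as a limit.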

Compound 3, half-maximal effective concentration: 28000 nM
For compound 3 the middle estimate is 2.1-fold (0.33 log units) above the measured one, within the range that was stated.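

At this position on a carbonyl carbon, 1-methyl-1,2,3,4-tetrahydroisoquinolin-2-yl gives the only read number among the amides shown: in this assay compound 3 gives 28000 nM, a value and not a limit. On these data alone, replacing benzyl(methyl)amino gives an at least 1.4-fold lower number from compound 2 to compound 3 (0.15 log units; that floor lies within the scatter), and replacing 2,3-dihydro-1H-indol-1-yl gives an at least 1.4-fold lower number from compound 1 to compound 3 (0.15 log units; that floor lies within the scatter), so a read number now stands, but neither step can be said to clear the usual scatter and the true size of each stays unknown. The other two amides remain limits of the assay and not numbers, so the series now holds one read number against two limits: the limit of > 40000 nM in this assay, at which 2 of the 3 values shown sit.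

Still open, as far as these compounds go, is whether the read number goes with the 1-methyl group or with the six-membered non-aromatic ring itself, a question that the plain 1,2,3,4-tetrahydroisoquinolin-2-yl amide or a 1-ethyl analogue would address. The compounds shown also leave open how this read-out responds to a primary amine or a carboxylic acid on the aromatic ring of this amide group.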